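The source may report more compounds than this note shows. Statements on the series, on what has been measured and on what is new or still open speak of the compounds shown alone.

Series notes, measured compounds:

- compound 1, `CO[C@@]12CCN(C)C[C@H]1[C@H](c1ccc(C)cc1)C(C#N)=C(N)O2`: in a functional assay on trachea (Cavia porcellus) (on this read-out lower numbers stand for stronger inhibition and higher numbers for weaker inhibition), compound 1 gives 13200 nM
- compound 2, `CCN1CC[C@@]2(OC)OC(N)=C(C#N)[C@@H](c3ccc(C)cc3)[C@@H]2C1`: in this assay compound 2 gives 16800 nM
- compound 3, `CO[C@@]12CCN(C)C[C@H]1[C@H](c1ccc(N3CCCCC3)cc1)C(C#N)=C(N)O2`: in this assay compound 3 gives 19000 nM

All three numbers lie within the usual scatter of one another, so no order among them is claimed. The two cores differ by piperidin-1-yl in place of methyl on an aromatic carbon, and that step read a 1.4-fold higher number from compound 1 to compound 3 (0.16 log units; within the scatter).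

Compound 4, `CCN1CC[C@@]2(OC)OC(N)=C(C#N)[C@@H](c3ccc(N4CCCCC4)cc3)[C@@H]2C1`, has not yet been measured in this assay. It differs from compound 3 by methyl in place of hydrogen on a saturated chain carbon bound to an amine nitrogen in a ring. The same change, (methyl in place of hydrogen on a saturated chain carbon bound to an amine nitrogen in a ring), was made earlier, where it gave a 1.3-fold higher number from compound 1 to compound 2 (0.10 log units; within the scatter). The step from compound 3 to compound 4 is expected to be a 1.3-fold higher number from compound 3 to compound 4 (0.10 log units; within the scatter) because the earlier pair gave a 1.3-fold higher number from compound 1 to compound 2 (0.10 log units; within the scatter) on an otherwise matched core. Within the data shown here, compound 4 is therefore estimated at 24000 nM in this assay, with a range from 10000 nM to 55000 nM; the single precedent leaves this uncertain.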

Compound 4, half-maximal inhibitory concentration: 13800 nM
Compound 4: middle estimate off by 1.7-fold (0.24 log units), on the high side; the measured number falls inside the stated range.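

In this assay, methyl in place of hydrogen on a saturated chain carbon bound to an amine nitrogen in a ring gave a 1.4-fold lower number from compound 3 to compound 4 (0.14 log units; within the scatter), and the two readings of this change on different cores do not separate: the same change on two cores in this assay, a 1.3-fold higher number (0.10 log units; within the scatter) from compound 1 to compound 2 and a 1.4-fold lower number (0.14 log units; within the scatter) from compound 3 to compound 4, 1.8-fold (0.24 log units) apart, within the scatter of two such steps. Piperidin-1-yl in place of methyl on an aromatic carbon gave a 1.2-fold lower number from compound 2 to compound 4 (0.09 log units; within the scatter), and its two readings do not separate either: the same change on two cores in this assay, a 1.4-fold higher number (0.16 log units; within the scatter) from compound 1 to compound 3 and a 1.2-fold lower number (0.09 log units; within the scatter) from compound 2 to compound 4, 1.8-fold (0.24 log units) apart, within the scatter of two such steps. Both changes therefore carry between these two cores without a detectable shift, but with every step inside the scatter, neither a direction nor a size is established for either change, and no claim extends to other cores.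

Still open, on these data alone, is whether any change at these places moves the number beyond the scatter. A longer chain in place of ethyl, or a carboxylic acid or an amine in place of piperidin-1-yl, would test this.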